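A phenoxy group added to a weakly active compound

The source may hold more compounds than are shown below. What is called first, only, known or untested is meant among the compounds shown, and "the series" means these compounds.

Compound 1 `S=C(Nc1ccccc1)Nc1ccc2[nH]ccc2c1`: > 30000 nM
Compound 2 `Oc1ccc(NC(=S)Nc2ccc3[nH]ccc3c2)cc1`: "not active" (no number reported)
Compound 3 `COc1ccc(NC(=S)Nc2ccc3[nH]ccc3c2)cc1`: 36000 nM

In an ADME assay on cells for inhibition of Amine oxidase [flavin-containing] A (Homo sapiens), read by spectrophotometry (a higher number here means a weaker inhibitor, a lower number a stronger inhibitor), compound 1 gives only a limit, > 30000 nM, not a measured number. Compound 3 gives 36000 nM in this assay, and compound 2 is reported as "not active" (no number reported). Compound 4 `S=C(Nc1ccc(Oc2ccccc2)cc1)Nc1ccc2[nH]ccc2c1` differs from compound 1 by phenoxy in place of hydrogen on an aromatic carbon. For the measured compounds named here, the only step that bears on this change, a step that the limit leaves unreadable from compound 1 to compound 3, also adds a group on that same aromatic carbon, yet its size cannot be read because compound 1 sits at the limit of > 30000 nM in this assay, at which 1 of the 3 values shown sits. Going by the values given here, no measured step therefore fixes a size or a direction for the move to compound 4 in this assay, and a weak result close to that limit is expected. Compound 4 is expected to give 30000 nM, within 8000 nM to 100000 nM. That estimate means an expected step of a number no higher from compound 1 to compound 4 (the limit leaves the size open).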

Compound 4, half-maximal inhibitory concentration: "not active" (no number reported)
No number was reported for compound 4, and the estimate cannot be compared.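

For the compounds shown here, compound 4 has no reported number and compound 1 has only a limit, so no step between them can be read. The compounds shown leave open whether phenoxy in place of hydrogen changes inhibition at all.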